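Swapping iodo for methyl on a potent compound

The source may report more compounds than this note shows. Statements on the series, on what has been measured and on what is new or still open speak of the compounds shown alone.

- compound 1 `Cc1cc(C)cc(Sc2c[nH]c3ccc(Cl)cc23)c1` gives 1200 nM in a functional assay on MCF7 cells (Homo sapiens) for inhibition, with a stated time of 48 h; on this read-out lower numbers stand for stronger inhibition and higher numbers for weaker inhibition
- compound 2 `COc1cc(Sc2c[nH]c3ccc(Cl)cc23)cc(OC)c1OC` gives 77 nM
- compound 3 `COc1cc(Sc2c[nH]c3ccc(I)cc23)cc(OC)c1OC` gives 68 nM

Compound 3 sits at the low end of these numbers, level with compound 2 within the scatter, and far from compound 1 at 1200 nM on this scale. Compound 4 `COc1cc(Sc2c[nH]c3ccc(C)cc23)cc(OC)c1OC` is not yet measured and has methyl in place of iodo on an aromatic carbon in the same place. Among the compounds with values here, the one measured step at this place is a 1.1-fold lower number from compound 2 to compound 3 (0.05 log units; within the scatter) and it stays within the scatter. Methyl is untested there, so only a modest step is expected in this assay, probably none beyond the scatter. The expected change is a 1.4-fold higher number from compound 3 to compound 4 (0.15 log units; within the scatter) as an estimate. For compound 4 the estimated value is 95 nM with an expected range from 40 nM to 250 nM as its limits.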

Compound 4, half-maximal inhibitory concentration: 16 nM
Beside the measured number, compound 4's estimate is 5.9-fold (0.77 log units) above it; the measured number lies below the stated range.
By their numbers in this assay, from the lowest: compound 4; then compounds 3 and 2 (each within the scatter of the next); then compound 1.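

Chloro and iodo gave numbers within the scatter of each other, so this place on the ring looked insensitive to the group it carries. Methyl breaks that picture: in this assay there is a 4.3-fold lower number from compound 3 to compound 4 (0.63 log units; beyond the scatter) and a 4.8-fold lower number from compound 2 to compound 4 (0.68 log units; beyond the scatter), so the place does respond to a change of group. No measurement on hand explains why.

From the compounds shown here alone, whether ethyl or an amine at this place would push the number lower remains open. So does whether methyl here would give a similar step on the core of compound 1.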